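From Methylphenyl to Difluorophenyl on the Sulfonamide Nitrogen

This account rests on a few compounds, and the source may have more. Where it says the series, first, only, none or still open, it means among the compounds named here.

In a functional assay on HT-29 cells (Homo sapiens) for antiproliferative activity, read by sulforhodamine B assay, with a stated time of 48 h (on this read-out lower numbers stand for stronger inhibition and higher numbers for weaker inhibition), compound 1 (`Cc1ccc(NS(=O)(=O)c2ccc(N3CCNC3=O)cc2)cc1`) gives 480 nM and sits close to compound 2 (`CCCCc1ccc(NS(=O)(=O)c2ccc(N3CCNC3=O)cc2)cc1`), which gives 610 nM here. Compound 3 (`CC(C)(C)c1ccc(NS(=O)(=O)c2ccc(N3CCNC3=O)cc2)cc1`) reports > 1000 nM as a limit, not a number. Compound 1 therefore shares the low end of these numbers with compound 2.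

Compound 4 (`O=C1NCCN1c1ccc(S(=O)(=O)Nc2ccc(F)c(F)c2)cc1`) differs from compound 1 at one place (3,4-difluorophenyl in place of 4-methylphenyl on a sulfonamide nitrogen): 3,4-difluorophenyl in place of 4-methylphenyl on a sulfonamide nitrogen. For the measured compounds named here, no measured compound carries fluorine, so the nearest guides are the changes made within that same group. One such step stayed small (a 1.3-fold higher number from compound 1 to compound 2 (0.10 log units; within the scatter)), and one was at least modest (an at least 2.0-fold higher number from compound 1 to compound 3 (0.31 log units; beyond the scatter)). On that basis, at most a slight rise is expected in this assay, with no step beyond the scatter. The expected step (a 1.3-fold higher number from compound 1 to compound 4 (0.10 log units; within the scatter)) stays small. Compound 4 is expected at 600 nM with a range from 200 nM to 1500 nM in this estimate.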

Compound 4, half-maximal inhibitory concentration: 350 nM
For compound 4 the middle estimate is 1.7-fold (0.23 log units) above the measured one; the range from low to high includes it.
By their numbers in this assay, from the lowest: compounds 4, 1 and 2 (each within the scatter of the next). At a limit, above all of these: compound 3.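

In this assay the swap on the sulfonamide nitrogen gives a 1.4-fold lower number from compound 1 to compound 4 (0.14 log units; within the scatter) and so shows no change beyond the usual scatter. A phenyl ring with fluorine and no alkyl group therefore serves at this position as well as the 4-methylphenyl, something compound 1, compound 2 and compound 3 could not show, since all three carry an alkyl group on that ring. Compound 3 remains the exception among these, with > 1000 nM as a limit and not a number.

The compounds shown offer no measured property that explains why the two rings read alike. Still open, on these data alone, is how a phenyl ring with a single fluorine, or one bearing an amine or a carboxylic acid, would read in this assay and whether either fluorine matters alone.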